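Methoxy on the Core: From Compound 3 to Compound 4

The compounds below may be only part of what the source reports. "The series", "measured", "known", "first", "only" and "open" are said of these compounds alone.

Of the compounds shown here, three of one family have been tested in a functional assay on SK-MEL cells (Homo sapiens) for cytotoxicity, read by MTT assay, with a stated time of 6 days; on this read-out higher numbers stand for an effect only at larger amounts of compound and lower numbers for an effect already at smaller amounts. Compound 1 `COC(=O)c1c(-c2ccc(O)cc2)oc2ccccc2c1=O` stops at a limit of the assay, giving > 25 ug/mL in this assay. Compound 2 `COC(=O)c1c(-c2ccc(O)cc2)oc2ccc(OC)cc2c1=O` carries methoxy in place of hydrogen on an aromatic carbon and gives 18.7 ug/mL in this assay, a step of an at least 1.3-fold lower number from compound 1 to compound 2 (0.12 log units; that floor lies within the scatter). Compound 3 `O=C(O)c1c(-c2ccc([N+](=O)[O-])cc2)oc2ccccc2c1=O` also stops at a limit, giving > 25 ug/mL in this assay. The difference between the core of compound 1 and the core of compound 3 is not broken down here. Two of the three values sit at the limit of > 25 ug/mL in this assay, at which 2 of the 3 values shown sit, so little can yet be said about how the methoxy group acts on this family.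

Compound 4 `COc1ccc2oc(-c3ccc([N+](=O)[O-])cc3)c(C(=O)O)c(=O)c2c1` is the untested member, differing from compound 3 by methoxy in place of hydrogen on an aromatic carbon, the same change as from compound 1 to compound 2. Compound 4 is expected to give about 25 ug/mL in this assay, most likely between 10 ug/mL and 50 ug/mL. The expected step of a number no higher from compound 3 to compound 4 (the limit leaves the size open) rests on the earlier step of an at least 1.3-fold lower number from compound 1 to compound 2 (0.12 log units; that floor lies within the scatter) and on compound 3 giving > 25 ug/mL, which makes a value that again stops at the limit quite possible.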

Compound 4, concentration for half-maximal effect: > 25 ug/mL
Compound 4: a limit, no number; the forecaster's own chance of this, stated with the estimate: 60%; the middle value sits exactly at the limit.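

Compound 3 and compound 4 both stop at a limit of this assay, so no step can be read between them. The compounds shown leave open what methoxy in place of hydrogen on an aromatic carbon does to the read-out in this family, and how far the compounds at the limit lie beyond it: the limit of > 25 ug/mL in this assay, at which 3 of the 4 values shown sit.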